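The source may hold more compounds than are shown below. What is called first, only, known or untested is meant among the compounds shown, and "the series" means these compounds.

Compound 1 `CN1CCN(CCNCc2cn(-c3ccc(F)cc3F)nc2-c2ccccc2)CC1` gives > 20000 nM in an ADME assay on Huh-7 cells (Homo sapiens) for cytotoxicity (a higher number here means that more compound is tolerated, a lower number that less compound is tolerated), which is a limit of the assay and not a number. Compound 2 `Cc1ccc(-c2nn(-c3ccc(F)cc3F)cc2CNCCN2CCN(C)CC2)cc1` gives > 20000 nM in this assay, again a limit of the assay. Compound 3 `CN1CCN(CCNCc2cn(-c3ccc(F)cc3F)nc2-c2cccc(Cl)c2)CC1` gives 15000 nM in this assay.

For the measured compounds named here, compound 3 therefore stands as the only compound of the three with an actual number; the other two sit at the limit of > 20000 nM in this assay, at which 2 of the 3 values shown sit. The step of an at least 1.3-fold lower number from compound 1 to compound 3 (0.12 log units; that floor lies within the scatter) and the step of an at least 1.3-fold lower number from compound 2 to compound 3 (0.12 log units; that floor lies within the scatter) both have their floor within the scatter, and the step that the two limits leave unreadable from compound 1 to compound 2 cannot be read at all.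

Compound 4 `COC(=O)c1ccc(-c2nn(-c3ccc(F)cc3F)cc2CNCCN2CCN(C)CC2)cc1` has not yet been measured in this assay. It differs from compound 3 by 4-(methoxycarbonyl)phenyl in place of 3-chlorophenyl on an aromatic carbon. The measured steps that touch this position are those from compound 1 and compound 2 to compound 3, and neither was large enough to be read as beyond the scatter. The change from compound 3 to compound 4 is therefore expected to give a step of a 1.2-fold higher number from compound 3 to compound 4 (0.08 log units; within the scatter) that stays within the scatter. On that basis compound 4 is expected to give about 18000 nM in this assay, with a likely range from 8000 nM to 45000 nM, and a fair chance that only a limit is reported.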

Compound 4, half-maximal cytotoxic concentration: > 20000 nM
Compound 4: a limit, no number; the forecaster's own chance of this, stated with the estimate: 50%; at least 1.1-fold (0.04 log units) between middle value and limit.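

Placing 4-(methoxycarbonyl)phenyl at this position, with its carbonyl and 2 hydrogen-bond acceptors, leaves the read-out in this assay at the assay's limit, as with the unsubstituted phenyl of compound 1 and the 4-methylphenyl of compound 2. The change gives an at least 1.3-fold higher number from compound 3 to compound 4 (0.12 log units; that floor lies within the scatter), so compound 4 cannot be set apart from compound 3, and the steps that join compound 4 to compound 1 and compound 2 cannot be read. The series now rests even more heavily on the single number from compound 3: the limit of > 20000 nM in this assay, at which 3 of the 4 values shown sit.

On these data alone, it remains open how far compound 1, compound 2 and compound 4 actually lie from compound 3. As far as these compounds go, it is equally open whether a carboxylic acid or an amine on this phenyl ring would give a number beyond the scatter from compound 3.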